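Extending a ring methyl to ethyl on the shared core

The source may report more compounds than this note shows. Statements on the series, on what has been measured and on what is new or still open speak of the compounds shown alone.

Measured so far:
- Compound 1, `CCOc1c(S(=O)(=O)CC)ccc(C(=O)c2c(C)ncn2O)c1Cl`: 20000 nM
- Compound 2, `CCOc1c(S(=O)(=O)CC)ccc(C(=O)c2c(C)nc(C)n2O)c1Cl`: 48 nM

In an assay on isolated protein for inhibition of 4-hydroxyphenylpyruvate dioxygenase (Arabidopsis thaliana) (on this read-out lower numbers stand for stronger inhibition and higher numbers for weaker inhibition), compound 1 gives 20000 nM, and compound 2 gives 48 nM. Among the compounds with values here, compound 2 therefore has the lowest number of the two; the only step measured on this core is a 420-fold lower number from compound 1 to compound 2 (2.62 log units; beyond the scatter), which adds a methyl group directly to an aromatic carbon of the core.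

Compound 3, `CCOc1c(S(=O)(=O)CC)ccc(C(=O)c2c(C)nc(CC)n2O)c1Cl`, is not yet measured. It differs from compound 2 by methyl in place of hydrogen on a saturated chain carbon bound to an aromatic carbon; read one bond further out, this is methyl to ethyl. Within the data shown here, no measured step of this kind exists here. The step from compound 1 to compound 2 concerns a different change, the first carbon on the ring, and gives no direct guide to lengthening that carbon into a chain. The expected outcome for compound 3 is therefore a step of a 1.0-fold higher number from compound 2 to compound 3 (0.02 log units; within the scatter) in this assay, close to compound 2 and likely within the scatter. Compound 3 is estimated at 50 nM, with a range from 15 nM to 200 nM.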

Compound 3, half-maximal inhibitory concentration: 71 nM
Beside the measured number, compound 3's estimate is 1.4-fold (0.15 log units) below it, within the range that was stated.
By their numbers in this assay, from the lowest: compounds 2 and 3 (each within the scatter of the next); then compound 1.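

In this assay, the step of a 1.5-fold higher number from compound 2 to compound 3 (0.17 log units; within the scatter) is the change from methyl to ethyl on this ring position, and it shows that one more carbon on the chain leaves the number indistinguishable from that of compound 2. The step of a 280-fold lower number from compound 1 to compound 3 (2.45 log units; beyond the scatter) shows that ethyl, like methyl, gives a large drop in the number compared with hydrogen at this place, so the benefit seen earlier is not unique to methyl. Nothing available speaks to the reason for either step.

On these data alone, whether this tolerance continues with a longer chain such as propyl or butyl, or with a branched group such as isopropyl, remains open. As far as these compounds go, it is also open whether a group that is not a plain carbon chain, such as an amine or a carboxylic acid, would be accepted here.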